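An Ethyl Group Takes the Place of Pyridin-4-yl

The source may hold more compounds than are shown below. What is called first, only, known or untested is meant among the compounds shown, and "the series" means these compounds.

In a functional assay on LNCaP cells (Homo sapiens) for cytotoxicity (a lower number here means a stronger inhibitor, a higher number a weaker inhibitor), compound 1 `O=C(Nc1ccc(-c2nc(N3CC4CCC(C3)O4)c3cnn(C4CCC5(CC4)OCCO5)c3n2)cc1)Nc1cccnc1` gives 1 nM, and compound 2 `O=C(Nc1ccncc1)Nc1ccc(-c2nc(N3CC4CCC(C3)O4)c3cnn(C4CCC5(CC4)OCCO5)c3n2)cc1` gives 1 nM, so the two stand level. Compound 3 `CCNC(=O)Nc1ccc(-c2nc(N3CC4CCC(C3)O4)c3cnn(C4CCC5(CC4)OCCO5)c3n2)cc1` carries ethyl in place of pyridin-4-yl on an amide-type nitrogen. For the measured compounds named here, only one measured step bears on this change. That step, no change at the digits printed from compound 1 to compound 2 (within the scatter), swaps pyridin-3-yl for pyridin-4-yl and stays within the scatter. Going by the values given here, it keeps an aromatic ring, whereas the present change removes one, so it offers weak guidance, and no measured compound lacks that ring. With compound 2 already at 1 nM, a weaker result, meaning a higher number, is the more likely direction. The expected change is moderate, at a 6.0-fold higher number from compound 2 to compound 3 (0.78 log units; beyond the scatter). For compound 3 the estimate is 6 nM, with an expected range of 1.5 nM to 30 nM.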

Compound 3, half-maximal inhibitory concentration: 1 nM
Compound 3: the middle estimate sits 6.0-fold (0.78 log units) above what was measured; measured number outside the range, below it.
By their numbers in this assay, from the lowest: compounds 1, 2 and 3 (each within the scatter of the next).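

In this assay, for the compounds shown here, replacing the ring with ethyl gives no change at the digits printed from compound 2 to compound 3 (within the scatter), which shows for the first time that this amide-type nitrogen can carry a group with no ring at all, where the earlier step had only exchanged one pyridinyl group for another. Set against the other pyridinyl compound, ethyl gives no change at the digits printed from compound 1 to compound 3 (within the scatter), so neither pyridin-3-yl nor pyridin-4-yl is required to hold the value at this level among these compounds. Nothing available explains why the smaller group leaves the value in place.

On these data alone, it remains open whether a longer chain such as hexyl, a benzyl group or a chain ending in a carboxylic acid would hold the same level on this nitrogen. Any difference among the three compounds finer than the printed digits also stays hidden.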